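Carbamate in place of chloropyridinyl amide on a benzothiazole

A few compounds are considered here, and "the series" means these few. Any claim that something is new, unique, unknown or untested is made for them only; others in the source may bear on it.

The three measured compounds share one core and differ only in the group on a carbonyl carbon attached to an amide-type nitrogen. In a functional assay on WI-38 VA13 cells (Homo sapiens) for cytotoxicity (on this read-out higher numbers stand for an effect only at larger amounts of compound and lower numbers for an effect already at smaller amounts), compound 1 `Cn1ncc([N+](=O)[O-])c1C(=O)Nc1ccc2nc(NC(=O)C3CCCCC3)sc2c1` gives 0.026 ug/mL. Compound 2 `O=C(Nc1nc2ccc(NC(=O)C3CCCO3)cc2s1)C1CCCCC1` gives 1.3 ug/mL, and compound 3 `O=C(Nc1ccc2nc(NC(=O)C3CCCCC3)sc2c1)c1cccnc1Cl` gives 0.075 ug/mL, which places compound 3 second of the three numbers, nearer to compound 1 than to compound 2.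

Compound 4 `C=CCOC(=O)Nc1ccc2nc(NC(=O)C3CCCCC3)sc2c1` is the next step from compound 3. The change is allyloxy in place of 2-chloropyridin-3-yl on a carbonyl carbon. Two earlier steps bear on it: when a heteroaromatic group was replaced by a small non-aromatic oxolan-2-yl, the result was a 50-fold higher number from compound 1 to compound 2 (1.70 log units; beyond the scatter), and the reverse kind of change, back to a heteroaromatic group, gave a 17-fold lower number from compound 2 to compound 3 (1.24 log units; beyond the scatter). Allyloxy, like oxolan-2-yl, is small and carries no ring, so a similar loss of potency is expected here, though an allyloxy group has not been tried on this core before and the size remains uncertain.

For compound 4 in this assay the expected step is an 11-fold higher number from compound 3 to compound 4 (1.03 log units; beyond the scatter), giving an estimate of 0.8 ug/mL with a likely range from 0.15 ug/mL to 4 ug/mL.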

Compound 4, half-maximal effective concentration: 0.58 ug/mL
Beside the measured number, compound 4's estimate is 1.4-fold (0.14 log units) above it; the measured number falls inside the stated range.
By their numbers in this assay, from the lowest: compound 1; then compound 3; then compound 4; then compound 2.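

In this assay, allyloxy, which carries no ring, gives a 7.7-fold higher number from compound 3 to compound 4 (0.89 log units; beyond the scatter) and a 22-fold higher number from compound 1 to compound 4 (1.35 log units; beyond the scatter), so the position tolerates the loss of either aromatic ring only at the cost of a clearly higher number. Within the data shown here, the two groups without an aromatic ring do not behave alike, as replacing oxolan-2-yl with allyloxy gives a 2.2-fold lower number from compound 2 to compound 4 (0.35 log units; beyond the scatter); across all four compounds, both groups with an aromatic ring still give lower numbers than both groups without one, and no compound goes against this order. Nothing available explains these differences or shows which feature of the groups is responsible.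

The compounds shown leave open whether the double bond of allyloxy plays any part, which a saturated propoxy group on the same carbonyl carbon would address, and whether the oxygen attached to that carbon matters, which a butyl chain or a dimethylamino group would address. They also leave open whether a plain phenyl ring would match the two heteroaromatic groups, and whether these steps would keep their size if the cyclohexyl group on the other amide were replaced.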